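The source may hold more compounds than are shown below. What is called first, only, known or untested is meant among the compounds shown, and "the series" means these compounds.

Compound 1, `CNC(=O)c1cc(Oc2ccc3sc(Nc4cccc(C(C)(C)C)c4)nc3c2)ccn1`, gives 10 10^-6 cm/s in an ADME assay on Caco-2 cells (Homo sapiens) for permeability, in the apical to basolateral direction; a higher number here means that the compound crosses the layer faster, a lower number that the compound crosses the layer more slowly.
Compound 2, `CNC(=O)c1cc(Oc2ccc3sc(Nc4ccc(Cl)cc4)nc3c2)ccn1`, gives 10 10^-6 cm/s in this assay.
Compound 3, `CNC(=O)c1cc(Oc2ccc3sc(Nc4ccc(C)cc4)nc3c2)ccn1`, gives 10 10^-6 cm/s in this assay.

Compound 3 stands level with the other two measured compounds: no change at the digits printed from compound 1 to compound 3 (within the scatter) and no change at the digits printed from compound 2 to compound 3 (within the scatter), both within the scatter, and the third measured step, no change at the digits printed from compound 1 to compound 2 (within the scatter), is likewise flat. All three measured steps change only the substituent on the phenyl ring attached to the nitrogen on the aromatic ring, and none of them moved the read-out beyond the scatter.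

Compound 4, `CCCCc1ccc(Nc2nc3cc(Oc4ccnc(C(=O)NC)c4)ccc3s2)cc1`, differs from compound 3 by propyl in place of hydrogen on a saturated chain carbon bound to an aromatic carbon. This is again a change on that same phenyl ring, so the three flat steps are the ones that bear on it. On that basis the step of no change at the digits printed from compound 3 to compound 4 (within the scatter) is expected to stay within the scatter. Compound 4 is therefore estimated to give about 10 10^-6 cm/s in this assay, with a range from 5 10^-6 cm/s to 20 10^-6 cm/s.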

Compound 4, apparent permeability: 10 10^-6 cm/s
For compound 4 middle estimate and measured number coincide at the digits printed; the range from low to high includes it.
By their numbers in this assay, from the lowest: compounds 1, 2, 3 and 4 (each within the scatter of the next).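

Lengthening the methyl of compound 3 to the butyl of compound 4 gives no change at the digits printed from compound 3 to compound 4 (within the scatter) in this assay, so at this place on the saturated chain carbon bound to an aromatic carbon, the read-out tolerates added chain length as well as the earlier swaps of substituent. Butyl in place of chloro gives no change at the digits printed from compound 2 to compound 4 (within the scatter), and 4-butylphenyl in place of 3-(tert-butyl)phenyl gives no change at the digits printed from compound 1 to compound 4 (within the scatter), which extends the flat set to all four compounds. Nothing given here accounts for this flat read-out.

The compounds shown leave open whether an amine, a carboxylic acid or a chain longer than butyl on this phenyl ring would keep the read-out level. They also leave open what an ethyl in place of the methyl on the amide would do, since all four compounds share that part.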